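The source may report more compounds than this note shows. Statements on the series, on what has been measured and on what is new or still open speak of the compounds shown alone.

Measured in a functional assay on SK-OV-3 cells (Homo sapiens) for cytotoxicity; on this read-out higher numbers stand for weaker inhibition of growth and lower numbers for stronger inhibition of growth:
- Compound 1 `COc1ccc(C2=C(c3cc(OC)c(OC)c(OC)c3)CC3CCCN3C2=O)cc1O`: > 100000 nM (a limit of the assay)
- Compound 2 `COc1ccc(C2=C(c3ccc(SC)cc3)CC3CCCN3C2=O)cc1OC(=O)C1CCCN1C(=O)OC(C)(C)C`: 10000 nM
- Compound 3 `CSc1ccc(C2=C(c3ccc(F)c(F)c3)C(=O)N3CCCC3C2)cc1`: 100 nM

Compound 1 gives > 100000 nM, which is a limit and not a number. Of the two true numbers, compound 3 at 100 nM holds the lower, and the gap to compound 2 at 10000 nM lies beyond the scatter.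

Compound 4 `COc1ccc(C2=C(c3ccc(SC)cc3)CC3CCCN3C2=O)cc1` has not yet been measured. It differs from compound 3 at one place, a double-bonded ring carbon, where 4-methoxyphenyl stands in place of 3,4-difluorophenyl: 4-methoxyphenyl in place of 3,4-difluorophenyl on a double-bonded ring carbon. The 4-(methylsulfanyl)phenyl group stays.

Among the measured compounds shown here, no measured pair isolates this change, so the expectation is tentative. It leans towards weaker growth inhibition because compound 2, which also has a methoxy-bearing ring on that carbon but differs further there, gives 10000 nM. In this assay the expected step is a 3.0-fold higher number from compound 3 to compound 4 (0.48 log units; beyond the scatter), a modest rise that probably lies beyond the scatter. Compound 4 is estimated at 300 nM, with an expected range from 40 nM to 3000 nM.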

Compound 4, concentration for 50% growth inhibition: 3000 nM
The estimate for compound 4 lay 10-fold (1.00 log units) below the measured number; measured number inside the range.
By their numbers in this assay, from the lowest: compound 3; then compound 4; then compound 2. At a limit, above all of these: compound 1.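

Replacing 3,4-difluorophenyl with 4-methoxyphenyl on the double-bonded ring carbon gives a 30-fold higher number from compound 3 to compound 4 (1.48 log units; beyond the scatter) in this assay, while the 4-(methylsulfanyl)phenyl group stays in place. This is the first comparison shown that changes only this position, and it shows that growth inhibition here depends strongly on which ring this carbon carries, even though the two groups have the same number of heavy atoms and each contains one six-membered aromatic ring of carbon only. Nothing measured here accounts for the size of this step.

With only these two groups compared at this carbon, the fluorine atoms and the methoxy group cannot be assessed separately. Going by these compounds, it also remains open how a 4-fluorophenyl or a 4-aminophenyl group at this position would stand in this assay.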